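This account rests on a few compounds, and the source may have more. Where it says the series, first, only, none or still open, it means among the compounds named here.

Three compounds share one core and differ only in the group on the piperidine amide carbonyl. In a functional assay on U2OS cells for antagonist activity at proto-oncogene Wnt-3 (Homo sapiens), read by a luciferase reporter, with a stated time of 18 h (on this read-out lower numbers stand for an effect already at smaller amounts and higher numbers for an effect only at larger amounts of compound), compound 1 `CN(C)CC(=O)N1CCC(NS(=O)(=O)c2cc(S(=O)(=O)c3ccccc3)ccc2C(F)(F)F)CC1` gives 280 nM, compound 2 `O=C(Cn1ccnc1)N1CCC(NS(=O)(=O)c2cc(S(=O)(=O)c3ccccc3)ccc2C(F)(F)F)CC1` gives 230 nM, and compound 3 `CC(=O)N1CCC[C@H]1C(=O)N1CCC(NS(=O)(=O)c2cc(S(=O)(=O)c3ccccc3)ccc2C(F)(F)F)CC1` gives 250 nM. Compound 3 thus sits between the other two, with a 1.1-fold higher number from compound 2 to compound 3 (0.04 log units; within the scatter) and a 1.1-fold lower number from compound 1 to compound 3 (0.05 log units; within the scatter), while a 1.2-fold lower number from compound 1 to compound 2 (0.09 log units; within the scatter) completes the set; all three steps lie within the scatter. Compound 4 `CN(C)c1ccc(C(=O)N2CCC[C@H]2C(=O)N2CCC(NS(=O)(=O)c3cc(S(=O)(=O)c4ccccc4)ccc3C(F)(F)F)CC2)cc1` carries 4-(dimethylamino)phenyl in place of methyl on a carbonyl carbon, so the acetyl becomes a (4-(dimethylamino)phenyl)carbonyl. Within the data shown here, no measured step alters this acetyl, so the nearest guidance is that changing the whole amide substituent moved nothing beyond the scatter. The expected step is a 1.1-fold higher number from compound 3 to compound 4 (0.03 log units; within the scatter). Compound 4 is therefore estimated at 270 nM, with a range from 110 nM to 700 nM.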

Compound 4, half-maximal effective concentration: 830 nM
For compound 4 the middle estimate is 3.1-fold (0.49 log units) below the measured one, outside the stated range (above it).
By their numbers in this assay, from the lowest: compounds 2, 3 and 1 (each within the scatter of the next); then compound 4.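

In this assay, among these compounds, putting 4-(dimethylamino)phenyl in place of methyl on this carbonyl carbon gives a 3.3-fold higher number from compound 3 to compound 4 (0.52 log units; beyond the scatter) and is the only step in the set beyond the scatter. The earlier changes to the group on the piperidine amide carbonyl had left the numbers within the scatter, so this outer position is the first shown to respond to what it carries. Nothing measured here explains this step.

The compounds shown leave open whether the phenyl ring or its dimethylamino group accounts for the step. An unsubstituted phenyl or a 4-methoxyphenyl on this carbonyl carbon would separate the two.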